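Compound 2 to compound 3: chloro in place of fluoro

The source may hold more compounds than are shown below. What is called first, only, known or untested is meant among the compounds shown, and "the series" means these compounds.

In an ADME assay on microsomes from liver (Canis lupus familiaris) for metabolic stability (a lower number here means that the compound disappears faster, a higher number that the compound lasts longer), compound 1 (`Nc1nc(NCCNc2ncc(-c3ncc[nH]3)c(-c3ccc(F)cc3F)n2)ccc1[N+](=O)[O-]`) gives > 0.5 h, which is a limit and not a number. Compound 2 (`Nc1nc(NCCNc2ncc(-c3ncc[nH]3)c(-c3cc(F)c(Cl)cc3F)n2)ccc1[N+](=O)[O-]`) gives > 0.5 h, which is also a limit. The series therefore stands at the limit of > 0.5 h in this assay, at which 2 of the 2 values shown sit, and compound 2 has no readable position within it.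

Compound 3 (`Nc1nc(NCCNc2ncc(-c3ncc[nH]3)c(-c3cc(F)c(Cl)cc3Cl)n2)ccc1[N+](=O)[O-]`) carries chloro in place of fluoro on an aromatic carbon, ortho to a large group: chloro in place of fluoro on an aromatic carbon. Among the compounds with values here, the only measured step that bears on this change is a step that the two limits leave unreadable from compound 1 to compound 2, which also alters the same phenyl group. It offers no size or direction to carry over, so no change beyond the usual scatter is expected in this assay. The expected step is a step that the limit leaves unreadable from compound 2 to compound 3, and this estimate rests on limits alone. The estimate for compound 3 is 0.6 h, with an expected range of 0.3 h to 1.2 h.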

Compound 3, half-life: > 0.5 h
Compound 3 gave a limit, no number; the forecaster's own chance of this, stated with the estimate: 70%; the middle value lies beyond the limit too.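

In this assay compound 3 gives > 0.5 h, which is a limit and not a number. Within the data shown here, no step among compound 1, compound 2 and compound 3 can be read: the limit of > 0.5 h in this assay, at which 3 of the 3 values shown sit. The compounds shown leave open the actual half-life of each and whether these phenyl changes alter it.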